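The source may report more compounds than this note shows. Statements on the series, on what has been measured and on what is new or still open speak of the compounds shown alone.

Measured compounds in an ADME assay on cells (Macrophage, Homo sapiens) for cytotoxicity, read by MTT assay, with a stated time of 24 h; a higher number here means that more compound is tolerated, a lower number that less compound is tolerated:

Compound 1 `CC(O)Cn1c([N+](=O)[O-])cnc1/C=C/c1cccc(Br)c1` gives 620 nM.
Compound 2 `CC(O)Cn1c([N+](=O)[O-])cnc1/C=C/c1cccc([N+](=O)[O-])c1` gives 430 nM.
Compound 3 `CC(O)Cn1c([N+](=O)[O-])cnc1/C=C/c1ccccc1Br` gives 490 nM.

Compound 4 `CC(O)Cn1c([N+](=O)[O-])cnc1/C=C/c1ccccc1[N+](=O)[O-]` has not yet been measured in this assay.

The change from compound 1 to compound 2 is nitro in place of bromo on an aromatic carbon. In this assay this gave a 1.4-fold lower number from compound 1 to compound 2 (0.16 log units; within the scatter).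

Compound 3 differs from compound 1 in the core: 2-bromophenyl in place of 3-bromophenyl on a double-bonded chain carbon bound to a double-bonded chain carbon. In this assay this gave a 1.3-fold lower number from compound 1 to compound 3 (0.10 log units; within the scatter). Compounds 2 and 3 both lie within the scatter of each other, so no order among the three measured compounds can be read from these numbers.

The change from compound 3 to compound 4 is nitro in place of bromo on an aromatic carbon. It is the same kind of change as that from compound 1 to compound 2, but the place is not the same: in compound 2 the entering group sits meta to a large group, in compound 4 it sits ortho to a large group. For the measured compounds named here, only one measured instance of this change exists, and none on the core of compound 3.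

Going by the values given here, for compound 4 the step in this assay is expected to be a 1.4-fold lower number from compound 3 to compound 4 (0.13 log units; within the scatter), resting on the single step of a 1.4-fold lower number from compound 1 to compound 2 (0.16 log units; within the scatter). Compound 4 is therefore estimated at 360 nM, within 190 nM to 700 nM.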

Compound 4, half-maximal cytotoxic concentration: 1090 nM
For compound 4 the middle estimate is 3.0-fold (0.48 log units) below the measured one, and the stated range ends below it.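

In this assay, nitro in place of bromo does not behave as one fixed step across these two cores: on the core of compound 3 it gives a 2.2-fold higher number from compound 3 to compound 4 (0.35 log units; beyond the scatter). The two instances point in opposite directions and cannot be treated as a single transferable value: the same change on two cores in this assay, a 1.4-fold lower number (0.16 log units; within the scatter) from compound 1 to compound 2 and a 2.2-fold higher number (0.35 log units; beyond the scatter) from compound 3 to compound 4, 3.2-fold (0.51 log units) apart, beyond the scatter of two such steps. This shows that, within this series, the step measured on the core of compound 1 did not carry over to the core of compound 3, but with one pair on each core it gives neither a general rule nor a cause for the difference.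

The compounds shown leave open whether the higher number in compound 4 is tied to nitro alone or would also appear with other groups ortho to a large group, such as an amine or a carboxylic acid. They also leave open whether the difference between the two cores would persist with a longer chain in place of the hydroxyl-bearing chain on the shared core.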